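A few compounds are considered here, and "the series" means these few. Any claim that something is new, unique, unknown or untested is made for them only; others in the source may bear on it.

Of the compounds shown here, three have been measured in a physicochemical assay for acid dissociation. Compound 1 `COc1ccc(Oc2ccc3c(NCCCNCc4cc(F)ccc4OC)ccnc3c2)cc1` gives 9.28 in this assay. Compound 3 `COc1cccc(CNCCCNc2ccnc3cc(Oc4ccc(Cl)cc4)ccc23)c1O` gives 9.28 in this assay. Compound 2 `CC(C)Cc1ccc2c(NCCCNCc3ccco3)ccnc2c1` gives 9.47 in this assay, the highest of the three numbers shown, although its gaps to compound 1 and to compound 3 both fall within the scatter, so the three readings cannot be told apart. Compound 4 `CC(C)CCc1ccc2c(NCCCNCc3ccco3)ccnc2c1` has not yet been measured in this assay. It differs from compound 2 in one place: isobutyl in place of isopropyl on a saturated chain carbon bound to an aromatic carbon. Within the data shown here, no measured pair shows a change of this kind, and the move from compound 2 to compound 4 is expected to give a step of no more than the scatter, no change at the digits printed from compound 2 to compound 4 (within the scatter). Compound 4 is therefore estimated at 9.47, with a range from 9.2 to 9.75.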

Compound 4, acid dissociation constant: 9.47
The estimate for compound 4 equals the measured number at the digits printed, within the range that was stated.
By their numbers in this assay, from the lowest: compounds 1, 3, 2 and 4 (each within the scatter of the next).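

Among these compounds, this pair gives the first direct reading at this position: in this assay, isobutyl in place of isopropyl on a saturated chain carbon bound to an aromatic carbon gives no change at the digits printed from compound 2 to compound 4 (within the scatter). At this place, then, exchanging one of these saturated hydrocarbon groups for the other leaves the read-out unmoved, at least in this single pair. Nothing available here accounts for this result.

From the compounds shown here alone, whether an amine, a carboxylic acid or a much longer chain at this place would move the number remains open. So does whether the same exchange would give the same result on a different core.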